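A few compounds are considered here, and "the series" means these few. Any claim that something is new, unique, unknown or untested is made for them only; others in the source may bear on it.

Compound 1, `CC(C)c1onc(-c2c(Cl)cccc2Cl)c1COc1ccc(-c2nc3ccc(C(=O)O)cc3n2CC(C)(C)C)cc1`, gives 13 nM in an assay on Huh-7 cells for agonist activity at Bile acid receptor (Homo sapiens), read by a luciferase reporter; on this read-out higher numbers stand for an effect only at larger amounts of compound and lower numbers for an effect already at smaller amounts.
Compound 2, `CC(C)c1onc(-c2c(Cl)cccc2Cl)c1COc1ccc(-c2nc3ccc(C(=O)O)cc3n2CC2CC2)cc1`, gives 19.4 nM in this assay.

Within the data shown here, on these two numbers compound 2 stands alongside compound 1: the only measured step, a 1.5-fold higher number from compound 1 to compound 2 (0.17 log units; within the scatter), does not separate them. That step swaps one saturated group on the ring nitrogen of the shared core for another, and the read-out barely moves.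

Compound 3, `CC(C)c1onc(-c2c(Cl)cccc2Cl)c1COc1ccc(-c2nc3ccc(C(=O)O)cc3n2C2CCC2)cc1`, is the next member. Its change from compound 2 is cyclobutyl in place of cyclopropylmethyl on an aromatic nitrogen. The group on the same ring nitrogen is again reshuffled, with no new atoms added or removed. Among the measured compounds shown here, since the one comparable step, a 1.5-fold higher number from compound 1 to compound 2 (0.17 log units; within the scatter), stayed within the scatter, a step of the same kind is expected here: a 1.1-fold higher number from compound 2 to compound 3 (0.05 log units; within the scatter), with no direction beyond the scatter. Compound 3 is therefore estimated at 22 nM in this assay, within 9 nM to 55 nM.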

Compound 3, half-maximal effective concentration: 14.4 nM
Estimate against measurement, compound 3: 1.5-fold (0.18 log units) above; low and high end bracket the measured number.
By their numbers in this assay, from the lowest: compounds 1, 3 and 2 (each within the scatter of the next).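

In this assay, cyclobutyl on the aromatic nitrogen gives a 1.3-fold lower number from compound 2 to compound 3 (0.13 log units; within the scatter), and against the neopentyl group of compound 1 it gives a 1.1-fold higher number from compound 1 to compound 3 (0.04 log units; within the scatter). The earlier pair carried a saturated group joined to this nitrogen through a chain carbon, whereas compound 3 has its ring bound to the nitrogen itself, and the read-out still stays within the scatter across all three compounds. No other measurement here bears on the reason for this sameness.

On these data alone, all three groups are made of carbon only, so it remains open whether a much smaller group such as methyl, a flat phenyl ring or a ring holding an amine would leave the number in place. The compounds shown therefore mark no limit to what this position accepts.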